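Adding one methyl to the chain of compound 2

A few compounds are considered here, and "the series" means these few. Any claim that something is new, unique, unknown or untested is made for them only; others in the source may bear on it.

Measured in a functional assay on SW480 cells (Homo sapiens) for antiproliferative activity, read by MTT assay, with a stated time of 48 h; a lower number here means a stronger inhibitor, a higher number a weaker inhibitor
compound 1 `CCCCCCCC(CCO)n1cnc2c(N)ncnc21` gives > 50000 nM (a limit)
compound 2 `CCCCCCCC(CCO)n1cnc2c(N)nc(Cl)nc21` gives > 50000 nM (a limit)

Compound 2 stands at > 50000 nM in this assay, which is a limit of the assay and not a number. For the measured compounds named here, compound 1 sits at the same limit, so the series so far offers the limit of > 50000 nM in this assay, at which 2 of the 2 values shown sit, and no readable potency. The next compound is compound 3 `CCCCCCCCC(CCO)n1cnc2c(N)nc(Cl)nc21`, and the change from compound 2 is methyl in place of hydrogen on a saturated chain carbon, eight bonds along the chain from an aromatic nitrogen. One measured step is available, a step that the two limits leave unreadable from compound 1 to compound 2, and it concerns chloro in place of hydrogen on an aromatic carbon, not the chain. Going by the values given here, its size cannot be read, and no measured pair shows what a change in chain length does. No step beyond the scatter is therefore expected in this assay, in either direction, and a reading at the limit again is the likeliest outcome. The estimate amounts to an expected step that the limit leaves unreadable from compound 2 to compound 3, resting on no readable step. For compound 3 the estimated value is 60000 nM, with an expected range of 25000 nM to 120000 nM.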

Compound 3, half-maximal inhibitory concentration: 13100 nM
Beside the measured number, compound 3's estimate is 4.6-fold (0.66 log units) above it, outside the stated range (below it).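

In this assay, for the compounds shown here, methyl in place of hydrogen on a saturated chain carbon, eight bonds along the chain from an aromatic nitrogen, is the first change with a size that can be stated: an at least 3.8-fold lower number from compound 2 to compound 3 (0.58 log units; beyond the scatter) is what it gives. This also shows that the chain is a place where one added carbon can move the number beyond the scatter, which the unreadable step for chloro in place of hydrogen could not show for any part of the series. Since compound 2 stands at a limit, the step has a lower bound only, and compound 3 is the one compound shown that leaves the limit: the limit of > 50000 nM in this assay, at which 2 of the 3 values shown sit.

From the compounds shown here alone, whether the trend goes on with a longer chain, such as ethyl or propyl in place of this methyl, remains open, as does whether an amine or a carboxylic acid at the same place would keep a readable potency. Also open is what the chloro contributes at this chain length, as the compounds shown hold no pair with this chain that differs in that one place alone.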